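The source may hold more compounds than are shown below. What is called first, only, known or untested is meant among the compounds shown, and "the series" means these compounds.

Measured compounds:
- compound 1, `O=C(/C=C\Nc1ccc2cc[nH]c2c1)c1nc(-c2ccc(C(F)(F)F)cc2)n2ccccc12`; > 30000 nM
- compound 2, `COc1ccc(N/C=C\C(=O)c2nc(-c3ccc(OC)cc3)n3ccccc23)cc1`; "not determined" (no result reported)

The series shares one core and varies the aryl group on the enaminone nitrogen. In a functional assay on A549 cells (Homo sapiens) for cytotoxicity, read by MTT assay, with a stated time of 48 h (a higher number here means a weaker inhibitor, a lower number a stronger inhibitor), compound 1 gives > 30000 nM; this is a limit of the assay, not a number, so compound 1 stands only as a compound without measurable inhibition at the top of the tested range (the limit of > 30000 nM in this assay, at which 1 of the 2 values shown sits). Within the data shown here, for compound 2 no result is reported in this assay, so nothing can be said about its standing, and no step between measured compounds is available.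

Compound 3, `O=C(/C=C\Nc1ccc(F)cc1)c1nc(-c2ccc(C(F)(F)F)cc2)n2ccccc12`, is not yet measured. It differs from compound 1 in one place: 4-fluorophenyl in place of 1H-indol-6-yl on an amine nitrogen. With compound 1 at a limit, the step to compound 3 can only be guessed; the expectation is for no step beyond the scatter, with a high chance that this assay again reports only a limit. The estimated step from compound 1 to compound 3 is a number no higher from compound 1 to compound 3 (the limit leaves the size open). Compound 3 is therefore expected near 30000 nM, within a range of 10000 nM to 100000 nM.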

Compound 3, half-maximal inhibitory concentration: > 30000 nM
Compound 3: a limit, no number; the forecaster's own chance of this, stated with the estimate: 70%; the middle value lies on the limit itself.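

No step can be read between compound 1 and compound 3, the exchange of 1H-indol-6-yl for 4-fluorophenyl, as each gives only a limit of the assay and not a number: the limit of > 30000 nM in this assay, at which 2 of the 3 values shown sit.

The compounds shown leave open whether any aryl group on the enaminone nitrogen gives a measurable value in this assay.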